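Triazole to Tetrazole: an Expected Small Step

The source may hold more compounds than are shown below. What is called first, only, known or untested is meant among the compounds shown, and "the series" means these compounds.

Of the compounds shown here, three have been measured in a functional assay on CHO cells for antagonist activity at prostaglandin E2 receptor EP3 subtype (Homo sapiens), read by cAMP accumulation; a higher number here means a weaker inhibitor, a lower number a stronger inhibitor. Compound 1 `CC(C)C(O)(C(=O)O)c1ccc(-c2ccc3ccccc3c2)[nH]c1=O` gives 1580 nM, compound 2 `CCn1ncc2c(F)cc(-c3ccc(C(CC)(CC)c4nnc[nH]4)c(=O)[nH]3)cc21` gives 29 nM, and compound 3 `CC(C)C(Cc1nnc[nH]1)c1ccc(-c2ccc3cccc(F)c3c2)[nH]c1=O` gives 17 nM. Compound 3 thus has the lowest number of the three; its value and that of compound 2 lie within the usual scatter of one another, so nothing can be said of their order, whereas compound 1 stands far beyond the scatter with a much higher number. Compound 4 `CC(C)C(Cc1nnn[nH]1)c1ccc(-c2ccc3cccc(F)c3c2)[nH]c1=O` has not yet been measured. It differs from compound 3 in one place: 1H-tetrazol-5-yl in place of 4H-1,2,4-triazol-3-yl on a saturated chain carbon, two bonds along the chain from an aromatic carbon. Among the measured compounds shown here, no pair of measured compounds differs in this way alone, so no measured step guides the expectation. Because compound 3 gives 17 nM and the change swaps one five-membered aromatic ring with hetero atoms for another, the step from compound 3 to compound 4 is expected to be a 1.1-fold lower number from compound 3 to compound 4 (0.05 log units; within the scatter), no larger than the scatter, in either direction. Compound 4 is therefore estimated at 15 nM, with a range from 5 nM to 50 nM.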

Compound 4, half-maximal inhibitory concentration: 134 nM
Compound 4: the middle estimate sits 8.9-fold (0.95 log units) below what was measured; measured number above the stated range.
By their numbers in this assay, from the lowest: compounds 3 and 2 (each within the scatter of the next); then compound 4; then compound 1.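

In this assay, the place on the saturated chain carbon, two bonds along the chain from an aromatic carbon, does not accept the two rings as equals: 1H-tetrazol-5-yl in place of 4H-1,2,4-triazol-3-yl gives a 7.9-fold higher number from compound 3 to compound 4 (0.90 log units; beyond the scatter), a step beyond the usual scatter. The two groups match in heavy atoms, hydrogen-bond donors and net charge as counted, and differ in their carbon, nitrogen and hydrogen-bond acceptor counts, so a match in those shared counts is not enough to keep the value of compound 3 here. No measurement at hand explains this step.

Going by these compounds, whether the same swap carries a step of this size on the core of compound 2 remains open. So does how an imidazole, a primary amide or a longer chain carrying the 4H-1,2,4-triazol-3-yl ring would fare at this place.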